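Swapping a furan ring for phenyl on the amide arm

This account rests on a few compounds, and the source may have more. Where it says the series, first, only, none or still open, it means among the compounds named here.

Of the compounds shown here, three sharing one core have been tested in an assay on isolated protein for inhibition of NEDD8-activating enzyme E1 regulatory subunit (Homo sapiens), read by Western blot, with stated times of 10 min and 30 min, tested at 25 uM; a lower number here means less inhibition, a higher number more inhibition at the concentration tested (going by the name of the read-out). Compound 1 `CCOC(=O)CNC(=O)c1cccc2nc(OCC)n(Cc3ccc(-c4ccccc4-c4nnn[nH]4)cc3)c12` gives 46.5%. Compound 2 `CCOc1nc2cccc(C(=O)Nc3ccncc3)c2n1Cc1ccc(-c2ccccc2-c2nnn[nH]2)cc1` gives 39.8%. Compound 3 `CCOc1nc2cccc(C(=O)NCc3ccco3)c2n1Cc1ccc(-c2ccccc2-c2nnn[nH]2)cc1` gives 37.5%. None of the three is separated from another beyond the usual scatter: a number 6.7 percentage points lower from compound 1 to compound 2 (within the scatter), a number 9 percentage points lower from compound 1 to compound 3 (within the scatter) and a number 2.3 percentage points lower from compound 2 to compound 3 (within the scatter) are all small, so compound 3 cannot be called weaker or stronger than its two neighbours on these numbers.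

Compound 4 `CCOc1nc2cccc(C(=O)NCc3ccccc3)c2n1Cc1ccc(-c2ccccc2-c2nnn[nH]2)cc1` has not yet been measured. It differs from compound 3 in one spot: phenyl in place of furan-2-yl on a saturated chain carbon bound to an amide-type nitrogen.

Within the data shown here, no measured step exchanges the furan-2-yl for phenyl, so the nearest guides are the two steps that alter the same amide arm. Both stayed within the scatter: a number 9 percentage points lower from compound 1 to compound 3 (within the scatter) and a number 2.3 percentage points lower from compound 2 to compound 3 (within the scatter). Three different groups on that arm gave three numbers that cannot be told apart, so the inhibition in this assay has stayed level across them . On that basis a step of a number 2.5 percentage points higher from compound 3 to compound 4 (within the scatter) is expected, meaning no movement beyond the scatter.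

Compound 4 is therefore estimated at 40%, with a range from 28% to 52%.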

Compound 4, a percentage reported as inhibition, at one concentration (the size of the read-out at that concentration, not a potency): 48.9%
Beside the measured number, compound 4's estimate is 8.9 percentage points below it; low and high end bracket the measured number.
By their numbers in this assay, from the lowest: compounds 3, 2, 1 and 4 (each within the scatter of the next, the first and the last beyond it).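

Among these compounds, on the amide arm, phenyl in place of furan-2-yl is the first exchange here to go beyond the scatter in this assay, with a number 11.4 percentage points higher from compound 3 to compound 4 (beyond the scatter), so this position is not entirely indifferent to the group it carries, even though that step is modest. The picture is still not a clear ranking, since the benzyl arm stays within the scatter of the other two arms, with a number 9.1 percentage points higher from compound 2 to compound 4 (within the scatter) and a number 2.4 percentage points higher from compound 1 to compound 4 (within the scatter), and only the furan-2-yl and phenyl pair can be told apart. Nothing at hand explains what separates these two rings.

Going by these compounds, whether the step depends on an aromatic ring remains open, as a cyclohexyl or a thiophen-2-yl group on the same saturated chain carbon would test that, and so does the effect of a carboxylic acid in place of ethoxycarbonyl. All these readings also come from one concentration, so they give the size of the inhibition there and not a potency, and they say nothing about changes elsewhere on the shared core.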